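The source may report more compounds than this note shows. Statements on the series, on what has been measured and on what is new or still open speak of the compounds shown alone.

Compound 1 `COc1ccc2c(=O)c(/C=C/C(=O)NCc3cccc(F)c3)coc2c1` carries a 3-fluorobenzyl group on its amide nitrogen. In a functional assay (QGY7701 cells, Homo sapiens) for inhibition, read by MTT assay, with a stated time of 48 h (on this read-out lower numbers stand for stronger inhibition and higher numbers for weaker inhibition), compound 1 gives 28600 nM. Compound 3 `O=C(/C=C/c1coc2cc(O)ccc2c1=O)Nc1ccccc1` gives 17900 nM in this assay, a number that sits within the usual scatter of that of compound 1. Compound 2 `COc1ccc(NC(=O)/C=C/c2coc3cc(O)ccc3c2=O)cc1` reaches only the limit of > 100000 nM in this assay, so its value is a limit rather than a number (the limit of > 100000 nM in this assay, at which 1 of the 3 values shown sits). Among the compounds with values here, the one measured step, an at least 5.5-fold lower number from compound 2 to compound 3 (0.74 log units; beyond the scatter), concerns the substituent on the aryl group of the amide nitrogen. Within the data shown here, compound 4 `COc1ccc2c(=O)c(/C=C/C(=O)Nc3ccc(C)cc3)coc2c1` differs from compound 1 by 4-methylphenyl in place of 3-fluorobenzyl on an amide-type nitrogen, a change no measured step matches directly. Compound 4 is therefore expected to give about 30000 nM in this assay, between 8000 nM and 100000 nM, a step of a 1.0-fold higher number from compound 1 to compound 4 (0.02 log units; within the scatter) not clearly beyond the scatter.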

Compound 4, half-maximal inhibitory concentration: 39300 nM
Estimate against measurement, compound 4: 1.3-fold (0.12 log units) below; the range from low to high includes it.
By their numbers in this assay, from the lowest: compounds 3, 1 and 4 (each within the scatter of the next, the first and the last beyond it). At a limit, above all of these: compound 2.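

In this assay the exchange on the amide-type nitrogen gives a 1.4-fold higher number from compound 1 to compound 4 (0.14 log units; within the scatter) and so stays within the scatter. The earlier step concerned only a substituent on the aryl group, whereas here the whole group on that nitrogen is exchanged on the core of compound 1, and 4-methylphenyl and 3-fluorobenzyl read alike. Nothing shown bears on why these two groups read alike. Still open, as far as these compounds go, is whether an amine or a carboxylic acid on the aryl group of that nitrogen would move the number in this assay.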